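Ester side chain of the lactone series: acetamido-valine analogue

A few compounds are considered here, and "the series" means these few. Any claim that something is new, unique, unknown or untested is made for them only; others in the source may bear on it.

Among the measured compounds shown here, in an assay on COS-7 cells for inhibition of diacylglycerol lipase-alpha (Homo sapiens), read by scintillation counting (on this read-out lower numbers stand for stronger inhibition and higher numbers for weaker inhibition), compound 2 `CCCCCCCCCCC[C@@H](C[C@@H]1OC(=O)[C@H]1CCCCCC)OC(=O)CCNC=O` gives 600 nM, the only number among the values shown. Compound 1 `CCCCCCCCCCC[C@@H](C[C@@H]1OC(=O)[C@H]1CCCCCC)OC(=O)CCC(C)C` returns a limit of the assay, > 25000 nM, which is the limit of > 25000 nM in this assay, at which 1 of the 2 values shown sits. The step from compound 1 to compound 2 is an at least 41-fold lower number from compound 1 to compound 2 (1.61 log units; beyond the scatter). Compound 3 `CCCCCCCCCCC[C@@H](C[C@@H]1OC(=O)[C@H]1CCCCCC)OC(=O)[C@@H](NC(C)=O)C(C)C` differs from compound 2 by 1-acetamido-2-methylpropyl in place of 2-(formylamino)ethyl on a carbonyl carbon. That single measured step bears on it only indirectly: the amide arriving in compound 2 is kept, but the isopropyl branch that compound 1 carried returns inside the entering group. A weakening step smaller than the measured one is therefore expected, a 2.5-fold higher number from compound 2 to compound 3 (0.40 log units; beyond the scatter). Compound 3 is estimated at 1500 nM, between 300 nM and 8000 nM.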

Compound 3, half-maximal inhibitory concentration: 460 nM
Estimate against measurement, compound 3: 3.3-fold (0.51 log units) above, and the stated range covers the measured number.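

On the carbonyl carbon, 1-acetamido-2-methylpropyl serves as well as 2-(formylamino)ethyl in this assay, the change being a 1.3-fold lower number from compound 2 to compound 3 (0.12 log units; within the scatter). An isopropyl branch alone therefore does not go with the weak result of the isopentyl ester: the step is an at least 54-fold lower number from compound 1 to compound 3 (1.73 log units; beyond the scatter). The value of compound 1 is a limit of the assay: the limit of > 25000 nM in this assay, at which 1 of the 3 values shown sits.

Open, as far as these compounds go, is how a free amine or a carboxylic acid would read in place of the acetamido group. Also open, from the compounds shown here alone, is whether the defined stereocentre of 1-acetamido-2-methylpropyl matters.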